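Working notes: the sulfur-chain extension from compound 3 to compound 4

The compounds below may be only part of what the source reports. "The series", "measured", "known", "first", "only" and "open" are said of these compounds alone.

The series holds compound 1 `COc1ccc(-n2c(S)nnc2-c2cc(OC)c(OC)c(OC)c2)cc1`, compound 2 `CCSc1nnc(-c2cc(OC)c(OC)c(OC)c2)n1-c1ccc(OC)cc1` and compound 3 `CCSc1nnc(-c2cc(OC)c(OC)c(OC)c2)n1-c1ccc(N(C)C)cc1`. In a functional assay on HT-29 cells (Homo sapiens) for inhibition, read by MTT assay, with a stated time of 48 h (a higher number here means a weaker inhibitor, a lower number a stronger inhibitor), compound 1 gives > 60000 nM, which is a limit of the assay and not a number. Compound 2 gives > 60000 nM, also a limit. Compound 3 gives > 60000 nM, again a limit. All three values sit at the limit of > 60000 nM in this assay, at which 3 of the 3 values shown sit. The two single-point steps are accordingly a step that the two limits leave unreadable from compound 1 to compound 2 and a step that the two limits leave unreadable from compound 2 to compound 3; neither reveals a size. Compound 3 therefore stands only at a limit, with no number to place it against its neighbours.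

Compound 4 `COc1cc(-c2nnc(SCC(=O)C3CC3)n2-c2ccc(N(C)C)cc2)cc(OC)c1OC` differs from compound 3 by cyclopropylcarbonyl in place of methyl on a saturated chain carbon bound to a sulfur. Going by the values given here, no measured step concerns this change: the two steps that exist, ethyl in place of hydrogen on a sulfur and dimethylamino in place of methoxy on an aromatic carbon, are both unreadable, and the cyclopropylcarbonyl has no precedent. The expected step of a number no higher from compound 3 to compound 4 (the limit leaves the size open) is thus a guess with no measured support, and the most likely outcome is another limit. Compound 4 is estimated at 60000 nM, within 15000 nM to 200000 nM.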

Compound 4, half-maximal inhibitory concentration: > 60000 nM
Compound 4 gave a limit, no number; the forecaster's own chance of this, stated with the estimate: 65%; the middle value lies on the limit itself.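

No size can be read for the change from compound 3 to compound 4: compound 4 gives > 60000 nM, a limit of the assay and not a number, as compound 3 does. The compounds shown leave open what would give a measurable value at all: the limit of > 60000 nM in this assay, at which 4 of the 4 values shown sit.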